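Replacing the aryl amide with a free piperidine in a sulfonamide series

The source may report more compounds than this note shows. Statements on the series, on what has been measured and on what is new or still open speak of the compounds shown alone.

Measured compounds:
compound 1, `O=C(c1ccc(C(F)(F)F)cc1)N1CCC(NS(=O)(=O)c2cc(S(=O)(=O)c3ccccc3)ccc2C(F)(F)F)CC1`, 400 nM
compound 2, `CN(C)c1ccc(C(=O)N2CCC(NS(=O)(=O)c3cc(S(=O)(=O)c4ccccc4)ccc3C(F)(F)F)CC2)cc1`, 300 nM
compound 3, `CC(C)(C)OC(=O)N1CCC(C(=O)N2CCC(NS(=O)(=O)c3cc(S(=O)(=O)c4ccccc4)ccc3C(F)(F)F)CC2)CC1`, 300 nM

Three sulfonamides have been tested in an assay on isolated protein for displacement of a labelled ligand from secreted frizzled-related protein 1 (Homo sapiens), read by fluorescence polarization, with a stated time of 30 min; a higher number here means a weaker inhibitor, a lower number a stronger inhibitor. Compound 1 gives the highest of the three numbers, though its gaps to compound 2 and compound 3 both lie within the scatter, so no ordering among them can be claimed.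

Compound 4, `O=C(C1CCNCC1)N1CCC(NS(=O)(=O)c2cc(S(=O)(=O)c3ccccc3)ccc2C(F)(F)F)CC1`, is not yet measured. It differs from compound 1 in one place: piperidin-4-yl in place of 4-(trifluoromethyl)phenyl on a carbonyl carbon.

Among the measured compounds shown here, the only step recorded on this carbonyl substituent is a 1.3-fold lower number from compound 1 to compound 2 (0.12 log units; within the scatter), which is within the scatter. Compound 3, which carries a substituted piperidin-4-yl on that carbonyl carbon, shows a number within the scatter of compound 1. Both observations point to this position tolerating substitution without a large shift in this assay.

Compound 4 is therefore expected to give about 350 nM, with a range of 120 nM to 1000 nM, a step of a 1.1-fold lower number from compound 1 to compound 4 (0.06 log units; within the scatter) that is estimated to fall within the scatter.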

Compound 4, half-maximal inhibitory concentration: 120 nM
Beside the measured number, compound 4's estimate is 2.9-fold (0.46 log units) above it, within the range that was stated.
By their numbers in this assay, from the lowest: compound 4; then compounds 2, 3 and 1 (each within the scatter of the next).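

In this assay, the substituent on the carbonyl carbon turns out to matter: piperidin-4-yl in place of 4-(trifluoromethyl)phenyl gives a 3.3-fold lower number from compound 1 to compound 4 (0.52 log units; beyond the scatter), and in place of 4-(dimethylamino)phenyl it gives a 2.5-fold lower number from compound 2 to compound 4 (0.40 log units; beyond the scatter), both modest but beyond the scatter, unlike the earlier step on this substituent. Hydrogen in place of tert-butoxycarbonyl on the amine nitrogen in the ring gives a 2.5-fold lower number from compound 3 to compound 4 (0.40 log units; beyond the scatter), so a substituent on that nitrogen also registers, which the earlier numbers alone could not show. The data in hand offer no explanation for these steps.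

As far as these compounds go, it remains open whether the gain follows the amine nitrogen or the non-aromatic ring itself. A cyclohexyl group on the carbonyl carbon, or a methyl group on that amine nitrogen, would bear on this question.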